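This account rests on a few compounds, and the source may have more. Where it says the series, first, only, none or still open, it means among the compounds named here.

Compound 1 `COc1ccc(Cn2c3c(c4ccccc4c2=O)CCOc2ccccc2-3)cc1` gives 4780 nM in a functional assay on HeLa cells (Homo sapiens) for cytotoxicity, read by sulforhodamine B assay; on this read-out lower numbers stand for stronger inhibition and higher numbers for weaker inhibition.
Compound 2 `COc1ccc(Cn2c3c(c4ccc(C)cc4c2=O)CCOc2ccccc2-3)cc1` gives 4540 nM in this assay.
Compound 3 `COc1ccc(Cn2c(-c3ccccc3O)c(Br)c3ccccc3c2=O)cc1` gives 36800 nM in this assay.

Compounds 1 and 2 share a core and differ only by methyl in place of hydrogen on an aromatic carbon; that change made a step of a 1.1-fold lower number from compound 1 to compound 2 (0.02 log units; within the scatter). Compound 3 has a different core, and the difference between the two cores is not broken down here. Its value in this assay is the highest of the three, beyond the scatter from both compound 1 and compound 2.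

Compound 4 `COc1ccc(Cn2c(-c3ccccc3O)c(Br)c3cc(C)ccc3c2=O)cc1` has not yet been measured. It arises from compound 3 by methyl in place of hydrogen on an aromatic carbon. This is the same kind of change as that from compound 1 to compound 2, but not the same: in compound 4 the methyl enters a ring that is part of a fused or bridged system of two rings, whereas in compound 2 it is part of a fused or bridged system of four rings.

Because a 1.1-fold lower number from compound 1 to compound 2 (0.02 log units; within the scatter) lay within the scatter, the expectation for compound 4 is a step of a 1.0-fold lower number from compound 3 to compound 4 (0.01 log units; within the scatter) in this assay. Compound 4 is thus estimated to give 36000 nM, with a range from 17000 nM to 75000 nM.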

Compound 4, half-maximal inhibitory concentration: 20400 nM
For compound 4 the middle estimate is 1.8-fold (0.25 log units) above the measured one; measured number inside the range.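

Methyl in place of hydrogen on an aromatic carbon made a 1.8-fold lower number from compound 3 to compound 4 (0.26 log units; within the scatter) in this assay, so on the core of compound 3 this change did not move the number beyond the usual scatter. Set beside the earlier step, the change behaved alike on both cores, with no difference that can be told apart from the noise of such measurements: the same change on two cores in this assay, a 1.1-fold lower number (0.02 log units; within the scatter) from compound 1 to compound 2 and a 1.8-fold lower number (0.26 log units; within the scatter) from compound 3 to compound 4, 1.7-fold (0.23 log units) apart, within the scatter of two such steps. This suggests that, in this assay, the methyl can be carried between these two cores with little effect on the number, but two pairs are a small sample, and they show neither that the same would hold on a further core nor why the two steps agree.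

Going by these compounds, whether a larger group on the same aromatic carbon, such as a longer chain, an amine or a carboxylic acid, would move the number beyond the scatter stays open. On these data alone, it is also open whether a methyl on another carbon of that ring would behave in the same way.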